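Series notes: sulfanyl substitution on the shared core

The source may hold more compounds than are shown below. What is called first, only, known or untested is meant among the compounds shown, and "the series" means these compounds.

Measured so far in a functional assay on MGC-803 cells (Homo sapiens) for inhibition, read by MTT assay, with a stated time of 72 h; on this read-out higher numbers stand for weaker inhibition and lower numbers for stronger inhibition:
compound 1 `Cc1cc(Nc2cc(-c3ccccc3)[nH]n2)n2ncnc2n1` — 21700 nM
compound 2 `Cc1ccc(Cn2ccc(Nc3cc(C)nc4nc(SCc5ccc(Br)cc5)nn34)n2)cc1` — 7420 nM

Compound 1 stands at the highest of the two numbers; the gap from compound 2 lies beyond the scatter. Compound 3 `COc1ccc(CSc2nc3nc(C)cc(Nc4cc(-c5ccccc5)[nH]n4)n3n2)cc1` is not yet measured. Against compound 1 its change is (4-methoxybenzyl)sulfanyl in place of hydrogen on an aromatic carbon. Within the data shown here, no step between measured compounds differing in one place is available, so the expectation rests on compound 2, which in this assay gives 7420 nM. A step toward stronger inhibition of moderate size is expected, a 3.1-fold lower number from compound 1 to compound 3 (0.49 log units; beyond the scatter). Compound 3 is expected at 7000 nM, with a range of 2500 nM to 20000 nM.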

Compound 3, half-maximal inhibitory concentration: 3170 nM
For compound 3 the middle estimate is 2.2-fold (0.34 log units) above the measured one; the range from low to high includes it.
By their numbers in this assay, from the lowest: compound 3; then compound 2; then compound 1.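

In this assay, the first step read at a single place in this series is a 6.8-fold lower number from compound 1 to compound 3 (0.84 log units; beyond the scatter), which comes with the entry of the (4-methoxybenzyl)sulfanyl group. The aromatic carbon between two ring nitrogen atoms therefore accepts this group, and inhibition strengthens with it. No measurement bearing on the cause of this step is available.

The compounds shown leave open whether the sulfur, the benzyl ring or the methoxy group carries the step. From the compounds shown here alone, how an amine or a plain methylsulfanyl group would read at this carbon also remains open.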